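Chloro for methoxy on a pyridazinone core

A few compounds are considered here, and "the series" means these few. Any claim that something is new, unique, unknown or untested is made for them only; others in the source may bear on it.

Compound 1, `COc1ccccc1N1CCN(CCCn2ncc(N3CCN(C(=O)c4ccco4)CC3)c(Cl)c2=O)CC1`: 20.4 nM
Compound 2, `O=C(c1ccco1)N1CCN(c2cnn(CCCN3CCN(c4ccccc4Cl)CC3)c(=O)c2Cl)CC1`: 3.5 nM
Compound 3, `COc1ccccc1N1CCN(CCCCn2nc(N3CCN(C(=O)c4ccco4)CC3)ccc2=O)CC1`: 180 nM

In an assay on cell membranes for binding affinity to Adrenergic receptor alpha-1 (Rattus norvegicus), read by radioligand binding (a higher number here means a weaker inhibitor, a lower number a stronger inhibitor), compound 1 gives 20.4 nM and compound 2 gives 3.5 nM. The difference between them is chloro in place of methoxy on an aromatic carbon, and it made a step of a 5.8-fold lower number from compound 1 to compound 2 (0.77 log units; beyond the scatter). Compound 3 has a core whose difference from that of compound 1 is not broken down here; in this assay compound 3 gives 180 nM, the highest of the three numbers.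

Compound 4, `O=C(c1ccco1)N1CCN(c2ccc(=O)n(CCCCN3CCN(c4ccccc4Cl)CC3)n2)CC1`, has not yet been measured. It differs from compound 3 by chloro in place of methoxy on an aromatic carbon, the same change as that from compound 1 to compound 2. Because compound 2 showed a 5.8-fold lower number from compound 1 to compound 2 (0.77 log units; beyond the scatter) from compound 1, a comparable step is expected here, a 5.1-fold lower number from compound 3 to compound 4 (0.71 log units; beyond the scatter), though the core differs and the step may not carry over fully. Compound 4 is therefore estimated at 35 nM, between 10 nM and 120 nM.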

Compound 4, inhibition constant: 7.9 nM
Beside the measured number, compound 4's estimate is 4.4-fold (0.65 log units) above it, and the stated range ends above it.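

In this assay, chloro in place of methoxy again came with a lower number, showing a 23-fold lower number from compound 3 to compound 4 (1.36 log units; beyond the scatter). The direction of the change held on both cores, but its size did not: the same change on two cores in this assay, a 5.8-fold lower number (0.77 log units; beyond the scatter) from compound 1 to compound 2 and a 23-fold lower number (1.36 log units; beyond the scatter) from compound 3 to compound 4, 3.9-fold (0.59 log units) apart, beyond the scatter of two such steps. These two pairs do not show which feature sets the size of the step, since compound 1 and compound 3 differ in more than one place.

The compounds shown leave open how a fluoro or a methyl group would compare on the same aromatic carbon. They also leave open whether the change would keep its direction on a core carrying a longer chain.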